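A few compounds are considered here, and "the series" means these few. Any claim that something is new, unique, unknown or untested is made for them only; others in the source may bear on it.

Of the compounds shown here, three built on a shared core have been tested in a functional assay on EC9706 cells (Homo sapiens) for cytotoxicity, read by MTT assay, with a stated time of 72 h; on this read-out higher numbers stand for weaker inhibition and lower numbers for stronger inhibition. Compound 1 `NC(=O)N1CCN(C(=S)SCc2cn(Cc3ccccc3F)nn2)CC1` gives 43100 nM. Compound 2 `CCN(C)C(=O)N1CCN(C(=S)SCc2cn(Cc3ccccc3F)nn2)CC1` gives 15600 nM, and compound 3 `CC(C)(C)NC(=O)N1CCN(C(=S)SCc2cn(Cc3ccccc3F)nn2)CC1` gives 87800 nM. On these numbers compound 2 stands lowest of the three: its nearest neighbour is compound 1, reached by a 2.8-fold lower number from compound 1 to compound 2 (0.44 log units; beyond the scatter), and its furthest is compound 3, reached by a 5.6-fold higher number from compound 2 to compound 3 (0.75 log units; beyond the scatter).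

Compound 4 `O=C(NC1CCCCC1)N1CCN(C(=S)SCc2cn(Cc3ccccc3F)nn2)CC1` has not yet been measured in this assay. It differs from compound 2 in one place: cyclohexylamino in place of ethyl(methyl)amino on a carbonyl carbon. Among the measured compounds shown here, two measured steps bear on this change. The step of a 5.6-fold higher number from compound 2 to compound 3 (0.75 log units; beyond the scatter) replaces the same ethyl(methyl)amino group with a carbamoyl-nitrogen substituent that carries a single carbon group and a hydrogen, and the step of a 2.0-fold higher number from compound 1 to compound 3 (0.31 log units; beyond the scatter) shows that adding a carbon group to an amide-type nitrogen that already carries hydrogen also moves the number upward. Both point the same way, so the account expects compound 4 to follow them with a step of a 3.2-fold higher number from compound 2 to compound 4 (0.51 log units; beyond the scatter) in this assay, upward, beyond the scatter, though its exact size is uncertain. Compound 4 is thus estimated to give 50000 nM in this assay, with a range from 20000 nM to 125000 nM.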

Compound 4, half-maximal inhibitory concentration: 84900 nM
Beside the measured number, compound 4's estimate is 1.7-fold (0.23 log units) below it; the range from low to high includes it.
By their numbers in this assay, from the lowest: compound 2; then compounds 1, 4 and 3 (each within the scatter of the next, the first and the last beyond it).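

In this assay, cyclohexylamino on this carbonyl carbon sets compound 4 clearly apart from the ethyl(methyl)amino group of compound 2, with a 5.4-fold higher number from compound 2 to compound 4 (0.74 log units; beyond the scatter). Cyclohexyl and tert-butyl on the amide-type nitrogen cannot be told apart here, with a 1.0-fold lower number from compound 3 to compound 4 (0.01 log units; within the scatter), so in this pair a six-membered non-aromatic ring of carbon only gives no reading distinct from that of tert-butyl. Set against the plain amino group of compound 1, cyclohexyl gives a 2.0-fold higher number from compound 1 to compound 4 (0.29 log units; within the scatter), a step that stays within the scatter, so it does not firmly support the upward move seen with tert-butyl.

The compounds shown leave open whether the lower number of compound 2 goes with the absence of the amide hydrogen or with the particular carbon groups it carries, and a methylamino or a diethylamino group on the same carbonyl carbon would help to separate these two readings. Nothing measured here offers an explanation for the differences among these compounds.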